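Replacing a Hydroxy with an Amino on the Shared Core

A few compounds are considered here, and "the series" means these few. Any claim that something is new, unique, unknown or untested is made for them only; others in the source may bear on it.

Measured compounds:
compound 1 `Nc1nc(O)nc2c1nc(O)n2Cc1ccccc1`, 0.1 uM
compound 2 `CCCSc1nc(N)c2nc(O)n(Cc3ccccc3)c2n1`, 0.01 uM

Of the compounds shown here, two have been measured in a functional assay (spleen, spleen) for activation, with Mus musculus as the target; a lower number here means that less compound is needed, a higher number that more compound is needed for the effect. Compound 1 gives 0.1 uM, the higher of the two numbers. Compound 2 gives 0.01 uM, and the step of a 10-fold lower number from compound 1 to compound 2 (1.00 log units; beyond the scatter) is the only measured one; it touches the same aromatic carbon that is changed here, but with a different group entering.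

Compound 3 `Nc1nc(N)c2nc(O)n(Cc3ccccc3)c2n1` is not yet measured. Its difference from compound 1 is amino in place of hydroxy on an aromatic carbon. Going by the values given here, no measured step shows an amino entering at this carbon, so the one step known, from compound 1 to compound 2, bears on the position but not on the group, and its size cannot be carried over. With one hydrogen-bond donor and one acceptor leaving and the same counts entering, the expected change is small: a step within the scatter, or at most a modest lowering of the number. The estimate for compound 3 in this assay is 0.08 uM, with a range from 0.025 uM to 0.3 uM, which means an expected step of a 1.3-fold lower number from compound 1 to compound 3 (0.10 log units; within the scatter).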

Compound 3, minimum effective concentration: 10 uM
Estimate against measurement, compound 3: 130-fold (2.10 log units) below; measured number outside the range, above it.
By their numbers in this assay, from the lowest: compound 2; then compound 1; then compound 3.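

The exchange of hydroxy for amino on this aromatic carbon, between two ring nitrogen atoms, proves far from neutral in this assay: it gives a 100-fold higher number from compound 1 to compound 3 (2.00 log units; beyond the scatter), although the leaving and entering groups have the same counts of heavy atoms, hydrogen-bond donors and hydrogen-bond acceptors, and neither carries a net charge. Going by these compounds alone, the comparison with propylsulfanyl at the same carbon widens the picture, with a 1000-fold higher number from compound 2 to compound 3 (3.00 log units; beyond the scatter), so the three groups order the numbers from propylsulfanyl through hydroxy to amino, and this carbon proves much more sensitive to its substituent than the single earlier step could show. Nothing available here bears on what lies behind this large sensitivity.

The three compounds leave open whether the low number of compound 2 depends on the sulfur link or on the length of the chain, which a propoxy group, a methylsulfanyl group or a butylsulfanyl group at this carbon would help to separate. They also leave open whether a propylamino group would stay close to compound 3 or move toward compound 2, showing whether the amino nitrogen or the missing chain matters more.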